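Swapping methyl for chloro on the benzothiazole core

The source may hold more compounds than are shown below. What is called first, only, known or untested is meant among the compounds shown, and "the series" means these compounds.

Measured compounds:
- compound 1 `Cc1ccc2nc(NC(=O)/C=C/c3ccc(Cl)cc3)sc2c1`: 152 umol/kg
- compound 2 `COc1ccc(/C=C/C(=O)Nc2nc3ccc(C)cc3s2)cc1`: 209 umol/kg
- compound 3 `Cc1ccc2nc(NC(=O)/C=C/c3ccccc3)sc2c1`: 380 umol/kg

Three compounds share a core and differ only on the outer aromatic ring. In a functional assay on the whole organism (Hindlimb, strain albino) with Mus musculus as the target, in the maximal electroshock model, with a stated time of 0.5 h (a lower number here means that less compound is needed, a higher number that more compound is needed for the effect), compound 1 gives the lowest of the three numbers. The step of a 1.4-fold higher number from compound 1 to compound 2 (0.14 log units; within the scatter) stays within the scatter, while the step of a 2.5-fold higher number from compound 1 to compound 3 (0.40 log units; beyond the scatter) goes beyond it, a modest rise. The step of a 1.8-fold higher number from compound 2 to compound 3 (0.26 log units; within the scatter) again lies within the scatter. Compound 1 therefore stands at the low end of this small set, separated clearly only from compound 3.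

Compound 4 `O=C(/C=C/c1ccc(Cl)cc1)Nc1nc2ccc(Cl)cc2s1` is the next compound, and it differs from compound 1 in a different place: chloro in place of methyl on an aromatic carbon. This change sits on the core, not on the outer ring where the three measured steps were made. Among the measured compounds shown here, none of the measured steps therefore bears directly on it; they show only that replacing one small group by another on an aromatic carbon moved this assay by little or by a modest amount. For compound 4 the expectation is consequently a step within the scatter, a 1.0-fold lower number from compound 1 to compound 4 (0.01 log units; within the scatter), with no clear direction. Compound 4 is estimated at 150 umol/kg, with a range from 75 umol/kg to 300 umol/kg.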

Compound 4, dose for half-maximal effect: 204 umol/kg
The estimate for compound 4 lay 1.4-fold (0.13 log units) below the measured number, within the range that was stated.
By their numbers in this assay, from the lowest: compounds 1, 4, 2 and 3 (each within the scatter of the next, the first and the last beyond it).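

Chloro in place of methyl on an aromatic carbon of the shared core gives a 1.3-fold higher number from compound 1 to compound 4 (0.13 log units; within the scatter) in this assay, the first step shown at this position rather than on the outer aromatic ring. In this one pair, the methyl group can therefore give way to a chloro group without a difference that can be told from the usual scatter of repeated measurements, so the two compounds cannot be ranked against each other in this assay. No measurement shown gives a reason for this outcome, so it stands as an observation without an explanation.

Only methyl and chloro have been seen at this position, so the compounds shown leave open what an amine, a carboxylic acid or a longer chain such as butyl would do there. Among the compounds shown here, the swap has also been seen only with a chloro group on the outer aromatic ring, and it remains open whether it would give a similar result with methoxy or hydrogen on that ring.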